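This account rests on a few compounds, and the source may have more. Where it says the series, first, only, none or still open, it means among the compounds named here.

Compound 1 `Cc1ccccc1-c1nc2cn(-c3cccc(C#N)c3)nc2c(=O)n1CC1CCCN(C(C)C)C1` carries an isopropyl group on the ring amine and a cyano group on the pendant aryl ring; in an assay on HEK293 cells for displacement of a labelled ligand from growth hormone secretagogue receptor type 1 (Homo sapiens), with a stated time of 60 min (a lower number here means a stronger inhibitor, a higher number a weaker inhibitor), compound 1 gives 32 nM. Compound 3 `COc1cccc(-n2cc3nc(-c4ccccc4C)n(CC4CCCN(C(C)C)C4)c(=O)c3n2)c1` differs from it only on that aryl ring, and in this assay compound 3 gives 1.8 nM; the step is an 18-fold lower number from compound 1 to compound 3 (1.25 log units; beyond the scatter). Compound 2 `CCO[C@@H](C)CN1CCC[C@H](Cn2c(-c3cccnc3C)nc3cn(-c4cccc(OC)c4)nc3c2=O)C1` keeps the methoxy-bearing aryl ring but carries a methylpyridyl group and a 2-ethoxypropyl on the ring amine; in this assay compound 2 gives 5 nM, the second highest of the three numbers, nearer to compound 3 than to compound 1.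

Compound 4 `COc1cccc(-n2cc3nc(-c4cccnc4C)n(C[C@H]4CCCN(Cc5cnco5)C4)c(=O)c3n2)c1` is compound 2 with 1,3-oxazol-5-yl in place of 1-ethoxyethyl on a saturated chain carbon bound to an amine nitrogen in a ring. Going by the values given here, the only measured step, from compound 1 to compound 3, changes the aryl substituent and not the group on the ring amine, so no measured step bears directly on this change. Compounds 2 and 3 differ on the ring amine as well as elsewhere, and their two values lie close together, so the chemist expects a step from compound 2 to compound 4 of only modest size, with no clear direction. The chemist therefore estimates that compound 4 gives 8 nM in this assay, with a range of 2 nM to 30 nM. This estimate corresponds to an expected step of a 1.6-fold higher number from compound 2 to compound 4 (0.20 log units; within the scatter).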

Compound 4, half-maximal inhibitory concentration: 120 nM
The estimate for compound 4 lay 15-fold (1.18 log units) below the measured number; measured number above the stated range.
By their numbers in this assay, from the lowest: compound 3; then compound 2; then compound 1; then compound 4.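

In this assay, replacing 1-ethoxyethyl with 1,3-oxazol-5-yl on a saturated chain carbon bound to an amine nitrogen in a ring gives a 24-fold higher number from compound 2 to compound 4 (1.38 log units; beyond the scatter), a large step beyond the scatter. Going by these compounds alone, the only earlier step, an 18-fold lower number from compound 1 to compound 3 (1.25 log units; beyond the scatter), lay on the aryl ring, so this is the first sign that the group on the ring amine can, on its own, shift the number by a large amount and towards a weaker inhibitor. The two groups have the same count of heavy atoms, so that count does not separate them; they differ in that an open chain with a defined stereocentre gives way to a five-membered aromatic ring with 2 hetero atoms.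

Nothing in the data shown explains why this exchange has so large an effect. As far as these compounds go, with only these groups at this place, it remains open where a benzyl group or a 2-aminoethyl chain on the ring amine would fall in this assay, and so whether the aromatic ring, the absence of the ether chain or something else goes with the higher number.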